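Swapping the Chlorophenyl for a Carboxypyridinyl Ether

The source may report more compounds than this note shows. Statements on the series, on what has been measured and on what is new or still open speak of the compounds shown alone.

Measured compounds:
- compound 1, `CC(CCNC(=O)c1c(Cl)cncc1Cl)N1CCC(C(Oc2ncccc2Cl)c2ccc(C(F)(F)F)cc2)CC1`: 16700 nM
- compound 2, `Cc1cccnc1OC(c1ccc(C(F)(F)F)cc1)C1CCN(C(C)CCNC(=O)c2c(Cl)cncc2Cl)CC1`: 33000 nM
- compound 3, `CC(CCNC(=O)c1c(Cl)cncc1Cl)N1CCC(C(Oc2ccccc2Cl)c2ccc(C(F)(F)F)cc2)CC1`: 4400 nM

The three compounds share a core and differ only in the aromatic ring attached through the ether oxygen. In an ADME assay on PBMC cells (Homo sapiens) for cytotoxicity (on this read-out lower numbers stand for higher toxicity in this test and higher numbers for lower toxicity in this test), compound 3 stands at the lowest of the three numbers, meaning it is the most toxic in this test: its steps to the others, a 3.8-fold lower number from compound 1 to compound 3 (0.58 log units; beyond the scatter) and a 7.5-fold lower number from compound 2 to compound 3 (0.88 log units; beyond the scatter), are both beyond the scatter.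

Compound 4, `CC(CCNC(=O)c1c(Cl)cncc1Cl)N1CCC(C(Oc2cccc(C(=O)O)n2)c2ccc(C(F)(F)F)cc2)CC1`, has not yet been measured. It differs from compound 3 in one place: 6-carboxypyridin-2-yl in place of 2-chlorophenyl on an oxygen on a saturated carbon

Among the measured compounds shown here, two measured steps bear on this change, since both compound 1 and compound 2 also replace the 2-chlorophenyl with a pyridin-2-yl ring carrying a small substituent. Read in that direction, those steps are modest rises in number, and the pair a 2.0-fold higher number from compound 1 to compound 2 (0.30 log units; within the scatter) lies within the scatter. Nothing here measures a carboxylic acid on that ring, so the size is uncertain, but a move to a pyridin-2-yl ring has so far gone toward higher numbers. Compound 4 is therefore expected to show a higher number than compound 3, estimated as a step of a 5.7-fold higher number from compound 3 to compound 4 (0.75 log units; beyond the scatter). The estimate for compound 4 is 25000 nM, with a range from 8000 nM to 80000 nM.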

Compound 4, half-maximal cytotoxic concentration: 28700 nM
Estimate against measurement, compound 4: 1.1-fold (0.06 log units) below; the measured number falls inside the stated range.
By their numbers in this assay, from the lowest: compound 3; then compounds 1, 4 and 2 (each within the scatter of the next).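

In this assay, the 6-carboxypyridin-2-yl group also moves away from the low number of the 2-chlorophenyl ring (a 6.5-fold higher number from compound 3 to compound 4 (0.81 log units; beyond the scatter)), now with a carboxylic acid on the pyridin-2-yl ring in place of a small chloro or methyl group. The size and kind of that substituent make no readable difference among these compounds, as a 1.1-fold lower number from compound 2 to compound 4 (0.06 log units; within the scatter) and a 1.7-fold higher number from compound 1 to compound 4 (0.24 log units; within the scatter) both show, so compound 3, the only one with a ring of carbon only, stands apart from the three pyridin-2-yl ethers. Nothing measured alongside these numbers explains this pattern.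

The four compounds do not separate the contribution of the ring nitrogen from that of the substituent, and a phenyl ring carrying the carboxylic acid or a pyridin-2-yl ring with no substituent would pull the two apart. Also open, on these data alone, is how a methyl ester or an aminomethyl group in place of the carboxylic acid would read in this assay.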